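Removing a Methoxy Group: Effect on Paw Edema Inhibition

A few compounds are considered here, and "the series" means these few. Any claim that something is new, unique, unknown or untested is made for them only; others in the source may bear on it.

Of the compounds shown here, three have been tested in a functional assay on the whole organism (strain albino) for inhibition, with Rattus norvegicus as the target, read by paw edema, with a stated time of 1 h, at a dose of 0.28 mmol/kg by the oral route; on this read-out higher numbers stand for more inhibition at the one dose given (going by the name of the read-out) and lower numbers for less inhibition. Compound 1 `COc1ccc(-c2nnc(SC/C(=N/O)c3ccccc3)n2-c2ccccc2)cc1` gives 58% in this assay; compound 2 `O/N=C(/CSc1nnc(-c2ccccc2)n1-c1ccccc1)c1ccccc1` gives 60%; compound 3 `CCn1c(SC/C(=N/O)c2ccccc2)nnc1-c1cc(OC)c(OC)c(OC)c1` gives 63%. The gaps among these three numbers all lie within the usual scatter of the measurement. The change from compound 1 to compound 2, (hydrogen in place of methoxy on an aromatic carbon), gave a number 2 percentage points higher from compound 1 to compound 2 (within the scatter). How the core of compound 1 differs from the core of compound 3 is not broken down here.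

Compound 4 `CCn1c(SC/C(=N/O)c2ccccc2)nnc1-c1ccc(OC)c(OC)c1` has not yet been measured. It differs from compound 3 by hydrogen in place of methoxy on an aromatic carbon. This is the same kind of change as that from compound 1 to compound 2, but not the same: there the departing methoxy sat para to a large group, whereas here it sits ortho to a methoxy group, meta to a large group and meta to a methoxy group. Because the earlier step of a number 2 percentage points higher from compound 1 to compound 2 (within the scatter) stayed within the scatter, the step from compound 3 to compound 4 is expected to be small as well, estimated as a number 1 percentage points lower from compound 3 to compound 4 (within the scatter). Compound 4 is thus expected to give about 62% in this assay, most likely between 50% and 72%.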

Compound 4, a percentage reported as inhibition, in the whole organism at one dose (the size of the read-out at that dose, not a potency): 61%
Compound 4: the middle estimate sits 1 percentage points above what was measured; low and high end bracket the measured number.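

Replacing one methoxy group with hydrogen in this assay gave a number 2 percentage points lower from compound 3 to compound 4 (within the scatter), so this second example of the change also produced no step larger than the normal variation between repeated measurements. On paper the two steps point in opposite directions, yet they cannot be told apart: the same change on two cores in this assay, a number 2 percentage points higher (within the scatter) from compound 1 to compound 2 and a number 2 percentage points lower (within the scatter) from compound 3 to compound 4, 4 percentage points apart, within the scatter of two such steps. On these two cores, then, the result of swapping a methoxy group for hydrogen carries over in the sense that both steps stay small, but two examples do not show that the same would hold on other cores, nor do they give any real direction for the change.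

The compounds shown leave open whether a different group on the same aromatic carbon, such as an amine or a carboxylic acid, would shift the number by more than the scatter. Each value also comes from one dose at one time point, so these readings say nothing about potency or about how the compounds would compare at other doses.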